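The source may hold more compounds than are shown below. What is called first, only, known or untested is meant among the compounds shown, and "the series" means these compounds.

In an ADME assay on HeLa Rh cells (Homo sapiens) for cytotoxicity, read by microscopy (on this read-out higher numbers stand for lower toxicity in this test and lower numbers for higher toxicity in this test), compound 1 `COc1ccc(-c2ccc(C(O)Cc3cc(OC)c(OC)cc3[N+](=O)[O-])cc2)cc1` gives > 244000 nM, and that figure is a limit of the assay rather than a measured number (the limit of > 244000 nM in this assay, at which 1 of the 3 values shown sits). Compound 2 `COc1cc(CC(O)c2ccc(-c3cccc(F)c3)cc2)c([N+](=O)[O-])cc1OC` gives 7400 nM in this assay, and compound 3 `COc1cc(CC(O)c2ccc(-c3cccc(CO)c3)cc2)c([N+](=O)[O-])cc1OC` gives 6000 nM. The two measured steps away from compound 1 run an at least 32-fold lower number from compound 1 to compound 2 (1.51 log units; beyond the scatter) and an at least 40-fold lower number from compound 1 to compound 3 (1.60 log units; beyond the scatter), while between the two replacements there is a 1.2-fold lower number from compound 2 to compound 3 (0.09 log units; within the scatter). Compound 4 `COc1cc(CC(O)c2ccc(-c3ccccc3C#N)cc2)c([N+](=O)[O-])cc1OC` differs from compound 1 in one place: 2-cyanophenyl in place of 4-methoxyphenyl on an aromatic carbon. Both measured steps that remove the 4-methoxyphenyl were large and in the same direction, so a comparable drop is expected for compound 4, namely an at least 30-fold lower number from compound 1 to compound 4 (1.48 log units; beyond the scatter). Compound 4 is therefore estimated at 8000 nM in this assay, with a range from 2500 nM to 30000 nM.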

Compound 4, half-maximal cytotoxic concentration: 9300 nM
Compound 4: the middle estimate sits 1.2-fold (0.07 log units) below what was measured; the range from low to high includes it.
By their numbers in this assay, from the lowest: compounds 3, 2 and 4 (each within the scatter of the next). At a limit, above all of these: compound 1.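

Replacing the 4-methoxyphenyl a third time again gives a large step, an at least 26-fold lower number from compound 1 to compound 4 (1.41 log units; beyond the scatter), now with 2-cyanophenyl, so the step is not confined to the fluoro and hydroxymethyl replacements. The nitrile compound stays level with both of them, with a 1.6-fold higher number from compound 3 to compound 4 (0.19 log units; within the scatter) and a 1.3-fold higher number from compound 2 to compound 4 (0.10 log units; within the scatter). The starting figure for compound 1 is a limit, so the full size of these large steps stays unknown: the limit of > 244000 nM in this assay, at which 1 of the 4 values shown sits.

From the compounds shown here alone, it remains open whether the methoxy group itself or its place on the ring matters, which 3-methoxyphenyl or plain phenyl would address. Going by these compounds, how an amine or a carboxylic acid on that ring would read also stays open.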